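The source may report more compounds than this note shows. Statements on the series, on what has been measured and on what is new or still open speak of the compounds shown alone.

Measured so far in a functional assay on MCF7 cells (Homo sapiens) for antiproliferative activity; on this read-out higher numbers stand for weaker inhibition and lower numbers for stronger inhibition:

- Compound 1 `Cc1cc(-c2nc3ccccc3s2)ccc1N`: < 1 nM, a limit
- Compound 2 `CC(=O)N(C(C)=O)c1ccc(-c2nc3ccccc3s2)cc1`: > 100 nM, a limit
- Compound 3 `O=C(CCl)Nc1ccc(-c2nc3ccccc3s2)cc1`: > 10 nM, a limit

None of these three results is an exact number. Compound 3 stands at > 10 nM, which is a limit. The next compound is compound 4 `O=C(Nc1ccc(-c2nc3ccccc3s2)cc1)C(Cl)Cl`, and the change is chloro in place of hydrogen on a saturated chain carbon bound to a carbonyl carbon and a chlorine atom. Chloro takes the place of hydrogen on a saturated chain carbon bound to a carbonyl carbon and a chlorine atom, so chloromethyl becomes dichloromethyl and ((chloromethyl)carbonyl)amino becomes ((dichloromethyl)carbonyl)amino.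

Among the compounds with values here, only one measured step touches this part of the molecule: a step that the two limits leave unreadable from compound 2 to compound 3. It swaps diacetylamino for ((chloromethyl)carbonyl)amino, and its size cannot be read. Compound 1 differs from compound 3 in more than one place, so it offers no clean comparison. Within the data shown here, no measured step replaces hydrogen with chloro, so the data give neither a size nor a direction for this change.

No shift beyond the usual scatter is therefore expected in this assay, and the result may again be only a limit. This expectation rests on compound 3, whose value of > 10 nM is a limit. The expected change is a step that the limit leaves unreadable from compound 3 to compound 4. For compound 4 the estimate is 30 nM, with an expected range of 10 nM to 300 nM.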

Compound 4, half-maximal inhibitory concentration: > 100 nM
Compound 4 gave a limit, no number (the forecaster's own chance of this, stated with the estimate: 50%); at least 3.3-fold (0.52 log units) between middle value and limit.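

In this assay compound 4 gives > 100 nM, which is a limit. Compound 2, compound 3 and compound 4 all stand at limits, so the steps from compound 3 to compound 4 and from compound 2 to compound 4 cannot be read. The compounds shown leave open whether chloro in place of hydrogen on this chain changes activity, and by how much.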